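Replacing a dichlorophenyl group with a fluorophenyl group

The compounds below may be only part of what the source reports. "The series", "measured", "known", "first", "only" and "open" are said of these compounds alone.

Compound 1 `CC1OC(=O)c2cc(C#N)c(N3CC(C(=O)NS(=O)(=O)Cc4ccccc4)C3)nc21`: > 300000 nM, a limit
Compound 2 `CN1Cc2nc(N3CCC(C(=O)NS(=O)(=O)Cc4ccccc4)CC3)c(C#N)cc2C1=O`: > 300000 nM, a limit
Compound 3 `N#Cc1cc2c(nc1N1CCC(C(=O)NS(=O)(=O)Cc3cc(Cl)cc(Cl)c3)CC1)COC2=O`: 30500 nM

Going by the values given here, in a functional assay (Platelet, plasma) for inhibition, with Homo sapiens as the target (a lower number here means a stronger inhibitor, a higher number a weaker inhibitor), compound 3 gives 30500 nM, the only value of the three that is a number rather than a limit. Compound 4 `N#Cc1cc2c(nc1N1CCC(C(=O)NS(=O)(=O)Cc3cccc(F)c3)CC1)COC2=O` differs from compound 3 in one place: 3-fluorophenyl in place of 3,5-dichlorophenyl on a saturated chain carbon bound to a sulfonyl sulfur. It has 3-fluorophenyl in place of 3,5-dichlorophenyl on a saturated chain carbon bound to a sulfonyl sulfur. Among the compounds with values here, no measured pair shows this change alone. Within the data shown here, compound 3, at 30500 nM, is the only measured compound carrying 3,5-dichlorophenyl, and losing that group is expected to weaken inhibition moderately. The estimated step is a 3.3-fold higher number from compound 3 to compound 4 (0.52 log units; beyond the scatter). The estimate for compound 4 is 100000 nM, within an expected range of 30000 nM to 300000 nM.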

Compound 4, half-maximal inhibitory concentration: 70500 nM
Compound 4: the middle estimate sits 1.4-fold (0.15 log units) above what was measured, and the stated range covers the measured number.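

In this assay, going by these compounds alone, this is the first step that can be read as a number: 3-fluorophenyl in place of 3,5-dichlorophenyl on a saturated chain carbon bound to a sulfonyl sulfur gives a 2.3-fold higher number from compound 3 to compound 4 (0.36 log units; beyond the scatter). So the two chlorines are not essential for measurable inhibition, although the change costs a modest amount of strength. Compound 4 still gives a number and does not sit at the limit of the assay: the limit of > 300000 nM in this assay, at which 2 of the 4 values shown sit.

Going by these compounds, this single step removes both chlorines and adds a fluorine, so the share of each change stays open. Also open, on these data alone, is how a 3-chlorophenyl group or a carboxylic acid would behave at the same place.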